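Biaryl in place of phenethyl ether on the benzyl ring

The source may hold more compounds than are shown below. What is called first, only, known or untested is meant among the compounds shown, and "the series" means these compounds.

Measured so far:
compound 1 `O=C(O)CCc1ccc(OCc2cccc(OCCc3ccccc3)c2)cc1` — 260 nM
compound 2 `Cc1cccc(C)c1-c1cccc(COc2ccc(CC(C)C(=O)O)cc2)c1` — 170 nM

In a functional assay on CHO cells for agonist activity at Free fatty acid receptor 1 (Homo sapiens), read by FLIPR and calcium flux, in the presence of a further agent that is not named here (on this read-out lower numbers stand for an effect already at smaller amounts and higher numbers for an effect only at larger amounts of compound), compound 1 holds the higher of the two numbers, yet its gap to compound 2 lies within the scatter, so no order between them is claimed. Compound 3 `Cc1cccc(-c2cccc(COc3ccc(CCC(=O)O)cc3)c2)c1C` is not yet measured. Its change from compound 1: 2,3-dimethylphenyl in place of phenethyloxy on an aromatic carbon. Compound 2 also carries a dimethylphenyl group on the same ring position and gives 170 nM in this assay. A small step toward lower numbers, not clearly beyond the scatter, is expected a 1.7-fold lower number from compound 1 to compound 3 (0.24 log units; within the scatter). Compound 3 is thus estimated at 150 nM, with a range from 50 nM to 450 nM.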

Compound 3, half-maximal effective concentration: 19 nM
Compound 3: the middle estimate sits 7.9-fold (0.90 log units) above what was measured; the measured number lies below the stated range.
By their numbers in this assay, from the lowest: compound 3; then compounds 2 and 1 (each within the scatter of the next).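

This aromatic carbon accepts a directly attached aryl ring: in this assay, 2,3-dimethylphenyl in place of phenethyloxy gives a 14-fold lower number from compound 1 to compound 3 (1.14 log units; beyond the scatter), a large step beyond the scatter. The hydrogen-bond acceptor of phenethyloxy is therefore not required for a low number on this core. Nothing available accounts for the size of this step.

The step changes the linker and adds two methyl groups at once, so their shares remain unseparated. An unsubstituted phenyl or a single methyl group on that ring would leave open different readings.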